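A few compounds are considered here, and "the series" means these few. Any claim that something is new, unique, unknown or untested is made for them only; others in the source may bear on it.

In an ADME assay on Vero cells (Chlorocebus sabaeus) for cytotoxicity, read by resazurin assay, with a stated time of 24 h (on this read-out higher numbers stand for lower toxicity in this test and lower numbers for higher toxicity in this test), compound 3 (`CC(C)CO[C@@H]1C=CC(=O)[C@@H](COC(=O)C(C)(C)C)O1`) gives 28200 nM and is the second highest of the three measured numbers. Compound 2 (`CC(=O)OC[C@H]1O[C@H](OC(C)C)C=CC1=O`) gives 104000 nM, the highest of the three, and compound 1 (`CCCCCO[C@@H]1C=CC(=O)[C@@H](COC(=O)C(C)(C)C)O1`) gives 7380 nM, the lowest of the three, on this read-out. The unmeasured compound 4 (`CC(C)O[C@@H]1C=CC(=O)[C@@H](COC(=O)C(C)(C)C)O1`) puts isopropyl in place of isobutyl on an oxygen on a saturated carbon. Going by the values given here, one measured step bears on this change: a 3.8-fold higher number from compound 1 to compound 3 (0.58 log units; beyond the scatter) is a modest step, beyond the scatter, and also alters the chain on that oxygen. Among the compounds with values here, compound 2 differs from compound 3 in more than one place and gives no clean step, so the expectation rests on a single pair. A modest move to a higher number is therefore expected in this assay (the size is uncertain). The estimated change is a 1.6-fold higher number from compound 3 to compound 4 (0.20 log units; within the scatter) and may not clear the scatter. Compound 4 is expected at 45000 nM with an estimated range from 20000 nM to 100000 nM in this read-out.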

Compound 4, half-maximal cytotoxic concentration: 12500 nM
Compound 4: the middle estimate sits 3.6-fold (0.56 log units) above what was measured; the whole stated range lies above it.
By their numbers in this assay, from the lowest: compounds 1 and 4 (each within the scatter of the next); then compound 3; then compound 2.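

In this assay, the chain on the oxygen does not act in one direction: isopropyl in place of isobutyl gives a 2.3-fold lower number from compound 3 to compound 4 (0.35 log units; beyond the scatter), against the earlier 3.8-fold higher number from compound 1 to compound 3 (0.58 log units; beyond the scatter), so compound 3 stands apart from both the longer pentyl and the shorter isopropyl chain. The pentyl-to-isopropyl change gives a 1.7-fold higher number from compound 1 to compound 4 (0.23 log units; within the scatter), so these two chains cannot be told apart here, and the series shows no steady trend with chain size. The first clean read at the other end of the molecule, tert-butyl in place of methyl on a carbonyl carbon, gives an 8.3-fold lower number from compound 2 to compound 4 (0.92 log units; beyond the scatter), but nothing available accounts for this step or for those on the oxygen.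

Still open, as far as these compounds go, is how a chain longer than pentyl, or one ending in an amine or a carboxylic acid, would read on that oxygen. From the compounds shown here alone, the tert-butyl step also rests on a single pair, so whether it holds with isobutyl or pentyl on the oxygen remains unknown.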